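A few compounds are considered here, and "the series" means these few. Any claim that something is new, unique, unknown or untested is made for them only; others in the source may bear on it.

Compound 2 `Cc1ccc2ncc(S(=O)(=O)c3ccc(Cl)cc3)c(N3CCC(C)CC3)c2c1` gives 79% in an assay on isolated protein for displacement of a labelled ligand from metabotropic glutamate receptor 5 (Homo sapiens), with a stated time of 60 min, tested at 1 uM (on this read-out higher numbers stand for more inhibition at the one concentration tested (going by the name of the read-out) and lower numbers for less inhibition), and compound 1 `Cc1ccc2ncc(S(=O)(=O)c3cc(Cl)cc(Cl)c3)c(N3CCC(C)CC3)c2c1` gives 75%, so the two stand level once the scatter is allowed for. Compound 3 `COc1cccc(S(=O)(=O)c2cnc3ccc(C)cc3c2N2CCC(C)CC2)c1` differs from compound 2 by 3-methoxyphenyl in place of 4-chlorophenyl on a sulfonyl sulfur. Among the measured compounds shown here, the only measured step at the sulfonyl sulfur is a number 4 percentage points higher from compound 1 to compound 2 (within the scatter), a change within the scatter, and no measured step covers a methoxy group. A step of similar small size, in no preferred direction, is therefore expected, namely a number 9 percentage points lower from compound 2 to compound 3 (within the scatter). Compound 3 is estimated at 70%, within a range from 45% to 88%.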

Compound 3, a percentage reported as inhibition, at one concentration (the size of the read-out at that concentration, not a potency): 96%
Estimate against measurement, compound 3: 26 percentage points below; the measured number lies above the stated range.
By their numbers in this assay, from the lowest: compounds 1 and 2 (each within the scatter of the next); then compound 3.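

The group on the sulfonyl sulfur can clearly move this read-out: 3-methoxyphenyl brings a number 17 percentage points higher from compound 2 to compound 3 (beyond the scatter) and a number 21 percentage points higher from compound 1 to compound 3 (beyond the scatter). The step between the two chlorine-bearing groups stayed within the scatter, so it gave no hint of this sensitivity. Nothing measured here explains the gain.

The compounds shown leave open whether the gain comes from the methoxy group itself or from where it sits on the phenyl ring. They also do not show whether an ethoxy group or a dimethylamino group would serve as well.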